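The source may hold more compounds than are shown below. What is called first, only, known or untested is meant among the compounds shown, and "the series" means these compounds.

Compound 1 `COc1ccc(-c2c(Nc3ccc(F)cc3)c3ccccc3oc2=O)cc1` and compound 2 `COc1ccc(-c2c(Nc3ccc(C)c(O)c3)c3ccccc3oc2=O)cc1` share one core and differ only in the group on the ring nitrogen. In a functional assay on HepG2 cells (Homo sapiens) for antiproliferative activity, read by MTT assay, with a stated time of 48 h (on this read-out higher numbers stand for weaker inhibition and lower numbers for stronger inhibition), compound 1 gives 35500 nM, and compound 2 gives 10200 nM. The change 3-hydroxy-4-methylphenyl in place of 4-fluorophenyl on a nitrogen on an aromatic ring brings a 3.5-fold lower number from compound 1 to compound 2 (0.54 log units; beyond the scatter). Compound 3 `COc1ccc2oc(=O)c(C(=O)C(F)(F)F)c(Nc3ccc(F)cc3)c2c1` is built on another core; the difference between the two cores is not broken down here. In this assay compound 3 reaches only a limit of the assay, > 100000 nM. Within the data shown here, it is the one compound that sits at the limit of > 100000 nM in this assay, at which 1 of the 3 values shown sits. Compound 4 `COc1ccc2oc(=O)c(C(=O)C(F)(F)F)c(Nc3ccc(C)c(O)c3)c2c1` carries the same change on the core of compound 3, (3-hydroxy-4-methylphenyl in place of 4-fluorophenyl on a nitrogen on an aromatic ring). The starting point here is only a limit, which leaves the step poorly anchored; if it resembled a 3.5-fold lower number from compound 1 to compound 2 (0.54 log units; beyond the scatter), the expected step would be an at least 1.6-fold lower number from compound 3 to compound 4 (0.22 log units; that floor lies within the scatter). Compound 4 is estimated at 60000 nM, between 25000 nM and 200000 nM, with a real chance that only a limit is reported again.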

Compound 4, half-maximal inhibitory concentration: 6710 nM
Compound 4: the middle estimate sits 8.9-fold (0.95 log units) above what was measured; the whole stated range lies above it.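

In this assay, the same change brings an at least 14-fold lower number from compound 3 to compound 4 (1.17 log units; beyond the scatter), so it lowers the number on both cores, but by clearly different amounts: the same change on two cores in this assay, a 3.5-fold lower number (0.54 log units; beyond the scatter) from compound 1 to compound 2 and an at least 14-fold lower number (1.17 log units; beyond the scatter) from compound 3 to compound 4, at least 4.2-fold (0.63 log units) apart, beyond the scatter of two such steps. From the compounds shown here alone, the value of compound 3 is only a limit, so the second step is a floor and its true size stays unknown: the limit of > 100000 nM in this assay, at which 1 of the 4 values shown sits. Two cores show that this change can carry over in direction but not in size, and they cannot predict its size on any further core.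

The compounds shown leave open whether the hydroxy group or the methyl group accounts for the step. They also leave open whether a methoxy group or an amine in place of that hydroxy group would give a similar step.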